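Dihydropyrimidinone curcuminoids: aryl change at the saturated ring carbon

This account rests on a few compounds, and the source may have more. Where it says the series, first, only, none or still open, it means among the compounds named here.

Measured so far in a functional assay, with a stated time of 20 min, tested at 2 uM; on this read-out higher numbers stand for a stronger effect at the one concentration tested and lower numbers for a weaker effect:
- compound 1 `COc1cc(/C=C/C(=O)C2=C(/C=C/c3ccc(O)c(OC)c3)NC(=O)NC2c2ccccc2)ccc1O` gives 10.5%
- compound 2 `COc1cc(/C=C/C(=O)C2=C(/C=C/c3ccc(O)c(OC)c3)NC(=O)NC2c2ccc(O)cc2)ccc1O` gives 33.3%
- compound 3 `COc1cc(/C=C/C(=O)C2=C(/C=C/c3ccc(O)c(OC)c3)NC(=O)NC2c2ccc(N(C)C)cc2)ccc1O` gives 28.2%

Compound 3 stands second highest of the three in this assay. Its nearest neighbour is compound 2, and the gap a number 5.1 percentage points lower from compound 2 to compound 3 (within the scatter) is within the scatter, so the two cannot be ordered. Its furthest neighbour is compound 1, and the step of a number 17.7 percentage points higher from compound 1 to compound 3 (beyond the scatter) is beyond the scatter, as is the parallel step a number 22.8 percentage points higher from compound 1 to compound 2 (beyond the scatter).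

Compound 4 `COc1cc(/C=C/C(=O)C2=C(/C=C/c3ccc(O)c(OC)c3)NC(=O)NC2c2c(Cl)cccc2Cl)ccc1O` differs from compound 3 in one place: 2,6-dichlorophenyl in place of 4-(dimethylamino)phenyl on a saturated ring carbon.

The step that bears on this change is a number 17.7 percentage points higher from compound 1 to compound 3 (beyond the scatter), which shows the read-out moving up on going from an unsubstituted phenyl to the 4-(dimethylamino)phenyl. Compound 4 removes that group again. For the measured compounds named here, no measured step shows what a 2,6-dichlorophenyl does in this assay, so the only anchor for the entering group is the level of compound 1, which carries an unsubstituted phenyl at the same saturated ring carbon. A step downward of modest size is therefore expected, roughly undoing a number 17.7 percentage points higher from compound 1 to compound 3 (beyond the scatter), though the chlorines leave this uncertain.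

For compound 4 the expected step is a number 13.2 percentage points lower from compound 3 to compound 4 (beyond the scatter), and the estimated value in this assay is 15%, with a range from 5% to 30%.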

Compound 4, a percentage reported as activity, at one concentration (the size of the read-out at that concentration, not a potency): 11.2%
For compound 4 the middle estimate is 3.8 percentage points above the measured one; measured number inside the range.
By their numbers in this assay, from the lowest: compounds 1 and 4 (each within the scatter of the next); then compounds 3 and 2 (each within the scatter of the next).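

In this assay, the 2,6-dichlorophenyl on the saturated ring carbon does not keep the higher level of the two other substituted aryl groups, with a number 17 percentage points lower from compound 3 to compound 4 (beyond the scatter) and a number 22.1 percentage points lower from compound 2 to compound 4 (beyond the scatter). Against the unsubstituted phenyl the step is a number 0.7 percentage points higher from compound 1 to compound 4 (within the scatter), so substitution on this aryl ring does not by itself raise the read-out: among the compounds shown, compound 2 and compound 3 stand above compound 1, while compound 4 goes against any such general trend. Nothing measured here accounts for the difference between these aryl groups.

The compounds shown change the substituent and its place on the aryl ring together, so they leave open whether the higher read-out follows the group or its place: 4-chlorophenyl and 2-hydroxyphenyl would separate the two. From the compounds shown here alone, it also remains open how far the 4-substituent can vary at this saturated ring carbon, for example with 4-methoxyphenyl, 4-aminophenyl or 4-carboxyphenyl in place of the 4-hydroxyphenyl and 4-(dimethylamino)phenyl groups.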